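The source may hold more compounds than are shown below. What is called first, only, known or untested is meant among the compounds shown, and "the series" means these compounds.

The measured compounds:

Compound 1, `CCC1=C(O)c2c(oc(-c3ccccc3C)cc2=O)C(CC)(CC)C1=O`, in a functional assay on KBVIN cells (Homo sapiens) for antiproliferative activity, read by sulforhodamine B assay, with a stated time of 3 days (on this read-out lower numbers stand for an effect already at smaller amounts and higher numbers for an effect only at larger amounts of compound), gives 2.41 uM.
Compound 2, `CCC1=C(O)c2c(oc(-c3ccc(OC)cc3C)cc2=O)C(CC)(CC)C1=O`, in this assay gives 2.62 uM.
Compound 3, `CCC1=C(O)c2c(oc(-c3ccc(OC)c(OC)c3)cc2=O)C(CC)(CC)C1=O`, in this assay gives 1 uM.

Compound 1 and compound 2 share a core and differ by one change, (methoxy in place of hydrogen on an aromatic carbon). This change gave a 1.1-fold higher number from compound 1 to compound 2 (0.04 log units; within the scatter), so the added methoxy left the read-out essentially where it was. Compound 3 carries two methoxy groups on its aromatic ring and no methyl, and in this assay compound 3 gives the lowest number of the three; the difference between the core of compound 3 and the core of compound 1 is not broken down here.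

Compound 4, `CCC1=C(O)c2c(oc(-c3cc(OC)c(OC)c(OC)c3)cc2=O)C(CC)(CC)C1=O`, has not yet been measured. It differs from compound 3 by methoxy in place of hydrogen on an aromatic carbon. This is the same kind of change as that from compound 1 to compound 2, but the surroundings are not the same: in compound 2 the new methoxy sits meta to a methyl group and para to a large group, whereas in compound 4 it sits ortho to a methoxy group, meta to a large group and meta to a methoxy group.

Among the measured compounds shown here, since the only measured example of this kind of change, a 1.1-fold higher number from compound 1 to compound 2 (0.04 log units; within the scatter), stayed within the scatter, compound 4 is expected to land close to compound 3, with an estimated step of a 1.2-fold higher number from compound 3 to compound 4 (0.08 log units; within the scatter). The estimate for compound 4 in this assay is 1.2 uM, expected to fall between 0.5 uM and 3 uM.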

Compound 4, concentration for half-maximal effect: 5.6 uM
The estimate for compound 4 lay 4.7-fold (0.67 log units) below the measured number; measured number outside the range, above it.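

On the core of compound 3, methoxy in place of hydrogen on an aromatic carbon gave a 5.6-fold higher number from compound 3 to compound 4 (0.75 log units; beyond the scatter) in this assay, a clear move towards a higher number, where the earlier example of this change had left the read-out essentially unchanged. The change therefore did not carry over from one core to the other with the same size, and the two steps differ by more than the scatter allows: the same change on two cores in this assay, a 1.1-fold higher number (0.04 log units; within the scatter) from compound 1 to compound 2 and a 5.6-fold higher number (0.75 log units; beyond the scatter) from compound 3 to compound 4, 5.2-fold (0.71 log units) apart, beyond the scatter of two such steps. Among the compounds shown here, this shows that the result of adding the methoxy cannot simply be read across from one core to another, but with only two examples it does not show which difference between the two cores, or between the surroundings of the new methoxy, accounts for the gap.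

The compounds shown leave open whether a hydroxyl, an amine or a longer chain such as ethoxy, placed ortho to a methoxy group and meta to a large group as in compound 4, would follow the same course as methoxy. They also leave open which of the two steps a third core carrying this change would resemble, if either.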